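This account rests on a few compounds, and the source may have more. Where it says the series, first, only, none or still open, it means among the compounds named here.

For the measured compounds named here, compound 3 `CCCCCCCSc1cc(-c2ccccc2)c(-c2ccccc2)nn1` gives 76000 nM in an assay on microsomes from liver for inhibition of sterol O-acyltransferase 1 (Rattus norvegicus) (a higher number here means a weaker inhibitor, a lower number a stronger inhibitor), the highest of the three numbers measured so far. Compound 2 `CCCCCCCNc1cc(-c2ccccc2)c(-c2ccccc2)nn1` gives 55000 nM, and the step of a 1.4-fold higher number from compound 2 to compound 3 (0.14 log units; within the scatter) lies within the scatter. Compound 1 `CCCCCCNc1cc(-c2ccccc2)c(-c2ccccc2)nn1` gives 24000 nM, and the step of a 3.2-fold higher number from compound 1 to compound 3 (0.50 log units; beyond the scatter) lies beyond it. Compound 4 `CCCCCCC[S+]([O-])c1cc(-c2ccccc2)c(-c2ccccc2)nn1` differs from compound 3 by a group of 9 heavy atoms (7 carbon, 1 oxygen, 1 sulfur; no ring) in place of a group of 8 heavy atoms (7 carbon, 1 sulfur; no ring), on an aromatic carbon. Going by the values given here, none of the measured steps involves the oxidized sulfur group that enters here; the nearest comparison, the swap of nitrogen for sulfur in a 1.4-fold higher number from compound 2 to compound 3 (0.14 log units; within the scatter), was small, and the chain lengthening a 2.3-fold higher number from compound 1 to compound 2 (0.36 log units; beyond the scatter) was modest. A step of about a 1.3-fold higher number from compound 3 to compound 4 (0.12 log units; within the scatter) in this assay is therefore expected, toward a weaker inhibitor if anything beyond the scatter. Compound 4 is estimated at 100000 nM, within a range from 30000 nM to 300000 nM.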

Compound 4, half-maximal inhibitory concentration: 77000 nM
The estimate for compound 4 lay 1.3-fold (0.11 log units) above the measured number, and the stated range covers the measured number.
By their numbers in this assay, from the lowest: compound 1; then compounds 2, 3 and 4 (each within the scatter of the next).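

Adding an oxygen to the sulfur of the heptylsulfanyl group barely moves the number in this assay: a 1.0-fold higher number from compound 3 to compound 4 (0.01 log units; within the scatter) is within the scatter. For the compounds shown here, the same holds for a 1.4-fold higher number from compound 2 to compound 4 (0.15 log units; within the scatter), so at this aromatic carbon the three heptyl-bearing groups cannot be told apart, while a 3.2-fold higher number from compound 1 to compound 4 (0.51 log units; beyond the scatter) is the only step here beyond the scatter, and its end groups also differ in chain length. Nothing available gives a reason for this. Still open, on these data alone, is how a sulfonyl group would read at this carbon, and whether a shorter chain on the oxidized sulfur, such as butyl, would give a lower number.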